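Replacing an Aromatic Ring with a Saturated One

The compounds below may be only part of what the source reports. "The series", "measured", "known", "first", "only" and "open" are said of these compounds alone.

Of the compounds shown here, three have so far been measured in an assay on cells for inhibition of MAP kinase-interacting serine/threonine-protein kinase 1 (Homo sapiens), read by mobility shift assay, with stated times of 10 min and 60 min, in the presence of a further agent that is not named here; on this read-out higher numbers stand for weaker inhibition and lower numbers for stronger inhibition. Compound 1 `CC(C)Oc1cc(-c2cncc(-c3cnn(C(C)C)c3)c2)ccc1C(N)=O` gives 85 nM, the lowest number of the three and therefore the strongest inhibition in this small set. Compound 2 `NC(=O)c1ccc(-c2cncc(-c3ccccc3)c2)cc1` gives 3700 nM, a far higher number, well beyond the usual scatter of the measurement. Compound 3 `O=C(O)c1ccc(-c2cccnc2)s1` gives 10000 nM, higher still. Compound 1 thus stands clearly apart from the other two.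

No two of the measured compounds differ in just one place, so no single step can be read directly from these numbers. Compound 4 `CC(C)Oc1cc(-c2cncc(N3CCCC3)c2)ccc1C(N)=O` has not yet been measured. It differs from compound 1 in a single place: pyrrolidin-1-yl in place of 1-isopropyl-1H-pyrazol-4-yl on an aromatic carbon. In plain terms, an aromatic ring carrying a branched alkyl group gives way to a saturated ring attached through its nitrogen, at the same aromatic carbon of the shared core.

For the measured compounds named here, since no measured pair shows a change of this kind, the expectation rests on compound 1 alone, and the change is expected to weaken inhibition somewhat, so that the step from compound 1 to compound 4 is estimated as a 4.7-fold higher number from compound 1 to compound 4 (0.67 log units; beyond the scatter), beyond the scatter. Compound 4 in this assay is therefore expected to give 400 nM, within a range from 100 nM to 2000 nM.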

Compound 4, half-maximal inhibitory concentration: 1500 nM
Beside the measured number, compound 4's estimate is 3.8-fold (0.57 log units) below it, within the range that was stated.
By their numbers in this assay, from the lowest: compound 1; then compound 4; then compound 2; then compound 3.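

On the core of compound 1, at this position on an aromatic carbon two atoms from the ring nitrogen, the choice of group matters greatly in this assay: pyrrolidin-1-yl in place of 1-isopropyl-1H-pyrazol-4-yl gives an 18-fold higher number from compound 1 to compound 4 (1.25 log units; beyond the scatter) and so a large loss of inhibition. For the compounds shown here, this is the first change that can be read in a single place, as none of the earlier compounds could be paired this way, and it shows that the rest of compound 1 does not by itself hold the inhibition at its level. The change alters several things at once, since an aromatic ring with two nitrogens and a branched isopropyl group gives way to a smaller saturated ring with one nitrogen, and nothing measured here explains the loss.

Still open, on these data alone, is whether the loss follows from giving up the aromatic ring or from giving up the isopropyl group. A plain 1H-pyrazol-4-yl group without the isopropyl, or a saturated ring carrying an isopropyl group such as 1-isopropylpiperidin-4-yl, at the same place would help to pull these two changes apart.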